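Fluoro to Trifluoromethyl on an Unchanged Core

A few compounds are considered here, and "the series" means these few. Any claim that something is new, unique, unknown or untested is made for them only; others in the source may bear on it.

Compound 1 `C=C1C[C@]23C[C@@]1(O)CC[C@@H]2c1cccc(C)c1[C@@H]3Cn1cc(-c2ccc(Br)cc2)nn1` and compound 2 `C=C1C[C@]23C[C@@]1(O)CC[C@@H]2c1cccc(C)c1[C@@H]3Cn1cc(-c2ccc(F)cc2)nn1` share one core and differ only on a six-membered aromatic ring. In a functional assay on A549 cells (Homo sapiens) for cytotoxicity, read by MTT assay, with a stated time of 4 days (a lower number here means a stronger inhibitor, a higher number a weaker inhibitor), compound 1 gives only a limit of the assay, > 20000 nM. Compound 2 likewise gives only a limit in this assay, > 20000 nM. The step that the two limits leave unreadable from compound 1 to compound 2 stays hidden because of the limit of > 20000 nM in this assay, at which 2 of the 2 values shown sit. Compound 3 `C=C1C[C@]23C[C@@]1(O)CC[C@@H]2c1cccc(C)c1[C@@H]3Cn1cc(-c2ccc(C(F)(F)F)cc2)nn1` carries the change (trifluoromethyl in place of fluoro on an aromatic carbon). For the measured compounds named here, no measured step bears on this change, so the expected step of a number no higher from compound 2 to compound 3 (the limit leaves the size open) is none beyond the scatter. Compound 3 is therefore estimated at 20000 nM, in a range from 5000 nM to 60000 nM.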

Compound 3, half-maximal inhibitory concentration: > 20000 nM
Compound 3 ended at the assay's limit; the forecaster's own chance of this, stated with the estimate: 75%; the middle value sits exactly at the limit.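

No step can be read among compound 1, compound 2 and compound 3, because all three stop at a limit of the assay: the limit of > 20000 nM in this assay, at which 3 of the 3 values shown sit.

On these data alone, whether bromo, fluoro or trifluoromethyl on this ring makes any difference in this assay stays open, as none of the three gives an actual number.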